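Urea substituent on the shared core: outlook for compound 4

This account rests on a few compounds, and the source may have more. Where it says the series, first, only, none or still open, it means among the compounds named here.

Measured so far in a functional assay on LNCaP cells (Homo sapiens) for cytotoxicity; a higher number here means a weaker inhibitor, a lower number a stronger inhibitor:
- compound 1 `CC(=O)Nc1ccc(-c2nc(N3CC4CCC(C3)O4)c3sccc3n2)cc1` gives 1700 nM
- compound 2 `O=C(Nc1ccc(-c2nc(N3CC4CCC(C3)O4)c3sccc3n2)cc1)Nc1cccnc1` gives 27 nM
- compound 3 `CNC(=O)Nc1ccc(-c2nc(N3CC4CCC(C3)O4)c3sccc3n2)cc1` gives 85 nM

Compound 3 stands second highest of the three numbers in this assay: nearest is compound 2, furthest is compound 1, with a 3.1-fold higher number from compound 2 to compound 3 (0.50 log units; beyond the scatter) and a 20-fold lower number from compound 1 to compound 3 (1.30 log units; beyond the scatter) both beyond the scatter.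

Compound 4 `O=C(Nc1ccncc1)Nc1ccc(-c2nc(N3CC4CCC(C3)O4)c3sccc3n2)cc1` differs from compound 3 in one place: pyridin-4-yl in place of methyl on an amide-type nitrogen. The measured step that bears on it most directly is the reverse of a 3.1-fold higher number from compound 2 to compound 3 (0.50 log units; beyond the scatter), where an aryl group on the same amide-type nitrogen gave the lower number. Both aryl and methyl urea variants lie far from the acetamide of compound 1, as a 63-fold lower number from compound 1 to compound 2 (1.80 log units; beyond the scatter) and a 20-fold lower number from compound 1 to compound 3 (1.30 log units; beyond the scatter) show, so the urea carries most of the gain, and the exchange of methyl for a pyridinyl ring adds a modest further step downward. Among the measured compounds shown here, no measured pair separates pyridin-4-yl from pyridin-3-yl, so that part of the change is uncertain.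

A modest step downward is therefore expected, a 2.8-fold lower number from compound 3 to compound 4 (0.45 log units; beyond the scatter), in this assay. For compound 4 the expected value is 30 nM, with a range of 12 nM to 90 nM.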

Compound 4, half-maximal inhibitory concentration: 10 nM
For compound 4 the middle estimate is 3.0-fold (0.48 log units) above the measured one; the measured number lies below the stated range.
By their numbers in this assay, from the lowest: compound 4; then compound 2; then compound 3; then compound 1.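

Notes on the urea substituent: in this assay, the placement of the ring nitrogen in the pyridinyl group on the amide-type nitrogen now registers, with pyridin-4-yl in place of pyridin-3-yl giving a 2.7-fold lower number from compound 2 to compound 4 (0.43 log units; beyond the scatter). The exchange of methyl for an aryl group on that nitrogen therefore does not have one fixed size, since pyridin-4-yl gives an 8.5-fold lower number from compound 3 to compound 4 (0.93 log units; beyond the scatter), whereas the step between the pyridin-3-yl and methyl ureas was only a 3.1-fold higher number from compound 2 to compound 3 (0.50 log units; beyond the scatter). Measured against the acetamide, the full change gives a 170-fold lower number from compound 1 to compound 4 (2.23 log units; beyond the scatter), which leaves compound 4 as the strongest of the four, with all of its steps beyond the scatter.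

Nothing available accounts for the difference between the two pyridinyl groups. Still open, going by these compounds, is how a plain phenyl ring, a pyridin-2-yl ring or a pyridin-4-yl ring carrying a methoxy group or an amine would compare on the same nitrogen, and whether the advantage of pyridin-4-yl would survive changes elsewhere on the shared core.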